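The source may report more compounds than this note shows. Statements on the series, on what has been measured and on what is new or still open speak of the compounds shown alone.

Working notes on the series, read in a functional assay on MCF7 cells (Homo sapiens) for cytotoxicity, read by MTT assay, with a stated time of 48 h; a higher number here means a weaker inhibitor, a lower number a stronger inhibitor. Compound 1 `Cc1ncc([N+](=O)[O-])n1CCSc1nnc(-c2ccc(N)cc2)o1` gives 19800 nM, compound 2 `CCOc1ccccc1-c1nnc(SCCn2c([N+](=O)[O-])cnc2C)o1` gives 25900 nM, and compound 3 `Cc1ncc([N+](=O)[O-])n1CCSc1nnc(-c2ccccc2[N+](=O)[O-])o1` gives 18300 nM. Compound 1 therefore lies within the scatter of both others. Compound 4 `Cc1ncc([N+](=O)[O-])n1CCSc1nnc(-c2ccc(Cl)cc2)o1` differs from compound 1 by one exchange: chloro in place of amino on an aromatic carbon, para to a large group. Within the data shown here, only one measured step bears on this, a 1.4-fold lower number from compound 2 to compound 3 (0.15 log units; within the scatter), which is a different exchange on an aromatic carbon and stays within the scatter. No step beyond the scatter is therefore expected in this assay. The estimate amounts to an expected 1.2-fold lower number from compound 1 to compound 4 (0.07 log units; within the scatter). For compound 4 the expected value is 17000 nM, with an estimated range from 8500 nM to 34000 nM.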

Compound 4, half-maximal inhibitory concentration: 18700 nM
For compound 4 the middle estimate is 1.1-fold (0.04 log units) below the measured one; the measured number falls inside the stated range.
By their numbers in this assay, from the lowest: compounds 3, 4, 1 and 2 (each within the scatter of the next).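

The step of a 1.1-fold lower number from compound 1 to compound 4 (0.02 log units; within the scatter) in this assay is the only one read at this position, para to a large group, and it lies within the scatter. Amino, with a hydrogen-bond donor and acceptor, and chloro, with neither, therefore give values within the scatter of each other here, which the step between compound 2 and compound 3, a different exchange, could not show. Nothing at hand explains this result.

On these data alone, whether a carboxylic acid, a dimethylamino group or a longer chain at this position would step beyond the scatter stays open.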